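Swapping 4-bromophenyl for 3,5-dimethylphenyl on the sulfur

The compounds below may be only part of what the source reports. "The series", "measured", "known", "first", "only" and "open" are said of these compounds alone.

Three compounds have been measured in a functional assay on A549 cells (Homo sapiens) for inhibition, read by CCK-8 assay, with a stated time of 72 h, tested at 2 uM (a lower number here means less inhibition of growth, a higher number more inhibition of growth at the concentration tested), so far:
- compound 1 `CCc1ccc(SCc2ccc(C(=O)Nc3ccccc3N)cc2)cc1` gives 53.6% here
- compound 2 `Cc1ccc(SCc2ccc(C(=O)Nc3ccccc3N)cc2)cc1` gives 40.5% here
- compound 3 `Nc1ccccc1NC(=O)c1ccc(CSc2ccc(Br)cc2)cc1` gives 33.2% here

Compound 3 at 33.2% sits within the scatter of compound 2, whereas a number 20.4 percentage points lower from compound 1 to compound 3 (beyond the scatter) goes beyond the scatter. Compound 4 `Cc1cc(C)cc(SCc2ccc(C(=O)Nc3ccccc3N)cc2)c1` is the next to be considered. Its change is 3,5-dimethylphenyl in place of 4-bromophenyl on a sulfur and so swaps the bromo for two methyl groups.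

For the measured compounds named here, three measured steps bear on this. Bromo in place of methyl gave a number 7.3 percentage points lower from compound 2 to compound 3 (within the scatter) and stayed within the scatter. Bromo in place of ethyl gave a number 20.4 percentage points lower from compound 1 to compound 3 (beyond the scatter) and was modest. Hydrogen in place of the chain methyl gave a number 13.1 percentage points lower from compound 1 to compound 2 (beyond the scatter) and was also modest. Going by the values given here, no measured compound carries two methyl groups, so this guide is rough. Still, the two compounds with carbon chains on the ring give no lower number than compound 3, which points to a modest rise. The expected step is a number 11.8 percentage points higher from compound 3 to compound 4 (beyond the scatter) in this assay and could shrink into the scatter. The estimate for compound 4 is 45% with an expected range from 30% to 60% around it.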

Compound 4, percent growth inhibition at one concentration: 33.3%
Beside the measured number, compound 4's estimate is 11.7 percentage points above it; the range from low to high includes it.
By their numbers in this assay, from the lowest: compounds 3, 4 and 2 (each within the scatter of the next); then compound 1.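

In this assay, putting 3,5-dimethylphenyl in place of 4-bromophenyl on the sulfur gives a number 0.1 percentage points higher from compound 3 to compound 4 (within the scatter) and so separates compound 4 from the bromo compound by no more than the usual scatter. Set against the 4-methylphenyl compound the change gives a number 7.2 percentage points lower from compound 2 to compound 4 (within the scatter) while against the 4-ethylphenyl compound it gives a number 20.3 percentage points lower from compound 1 to compound 4 (beyond the scatter) and so, among these four, only compound 1 stands apart, which shows that methyl groups on this ring do not match the number seen with the ethyl group. No measurement shown here explains these numbers.

Still open, going by these compounds, is whether a longer chain such as propyl on this ring would go with compound 1 or with the other three. An amine or a carboxylic acid on the ring also remains to be compared.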